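The compounds below may be only part of what the source reports. "The series", "measured", "known", "first", "only" and "open" are said of these compounds alone.

Measured compounds:
- compound 1, `CCCSc1nc2nc(C)cc(N3CC[C@@H](C)[C@@H](N(C)c4ncnc5[nH]ccc45)C3)n2n1`: 20900 nM
- compound 2, `C=CCSc1nc2nc(C)cc(N3CC[C@@H](C)[C@@H](N(C)c4ncnc5[nH]ccc45)C3)n2n1`: 35200 nM
- compound 3, `Cc1cc(N2CC[C@@H](C)[C@@H](N(C)c3ncnc4[nH]ccc34)C2)n2nc(SCc3ccccc3Br)nc2n1`: 21300 nM

All three share one core and differ only in the group on a saturated chain carbon bound to a sulfur. In a functional assay on HGC-27 cells (Homo sapiens) for inhibition, read by MTT assay, with a stated time of 72 h (on this read-out lower numbers stand for stronger inhibition and higher numbers for weaker inhibition), compound 1 gives 20900 nM, compound 2 gives 35200 nM and compound 3 gives 21300 nM. Compound 3 stands second highest of the three, but every step among them is within the scatter: a 1.7-fold higher number from compound 1 to compound 2 (0.23 log units; within the scatter), a 1.0-fold higher number from compound 1 to compound 3 (0.01 log units; within the scatter), a 1.7-fold lower number from compound 2 to compound 3 (0.22 log units; within the scatter). Among the compounds with values here, nothing measured so far separates ethyl, vinyl and 2-bromophenyl at this position.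

Compound 4, `Cc1cc(N2CC[C@@H](C)[C@@H](N(C)c3ncnc4[nH]ccc34)C2)n2nc(SCc3ccc([N+](=O)[O-])cc3)nc2n1`, is the next variation at the same place. Compared with compound 3: 4-nitrophenyl in place of 2-bromophenyl on a saturated chain carbon bound to a sulfur

Within the data shown here, the steps that bear on this change are those exchanging the group on the saturated chain carbon bound to the sulfur, and all of them stayed within the scatter. Among the measured compounds shown here, no measured step supports any movement beyond the scatter, so a step of about a 1.0-fold higher number from compound 3 to compound 4 (0.01 log units; within the scatter) is expected, with compound 4 estimated at 22000 nM in this assay, between 8000 nM and 60000 nM.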

Compound 4, half-maximal inhibitory concentration: 29400 nM
Beside the measured number, compound 4's estimate is 1.3-fold (0.13 log units) below it; the range from low to high includes it.
By their numbers in this assay, from the lowest: compounds 1, 3, 4 and 2 (each within the scatter of the next).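

In this assay, 4-nitrophenyl, the only group shown here that carries hydrogen-bond acceptors, remains within the scatter of all three earlier groups: a 1.4-fold higher number from compound 3 to compound 4 (0.14 log units; within the scatter), a 1.2-fold lower number from compound 2 to compound 4 (0.08 log units; within the scatter) and a 1.4-fold higher number from compound 1 to compound 4 (0.15 log units; within the scatter). The result extends the flat picture at the saturated chain carbon bound to the sulfur from ethyl, vinyl and 2-bromophenyl to a second substituted phenyl, so neither swapping 2-bromobenzyl for 4-nitrobenzyl nor adding these acceptors separates compound 4 from the others. No supporting data bear on why the read-out stays flat across these groups.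

As far as these compounds go, it remains open whether a group of another kind at this place, such as an amine, a carboxylic acid or a longer chain, would move the number beyond the scatter. The effects of bromine and nitro at a single ring position also remain unseparated, as 2-bromophenyl and 4-nitrophenyl differ in both the substituent and its placement.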